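The source may hold more compounds than are shown below. What is called first, only, known or untested is meant among the compounds shown, and "the series" means these compounds.

Measured compounds:
compound 1 `CCCc1cc(C)c(C(=O)N=C(N)N)cc1S(C)(=O)=O` — in a functional assay for inhibition of sodium/hydrogen exchanger (Oryctolagus cuniculus) (on this read-out higher numbers stand for weaker inhibition and lower numbers for stronger inhibition), compound 1 gives 5.7 nM
compound 2 `Cc1cc(Sc2ccccc2Cl)c(S(C)(=O)=O)cc1C(=O)N=C(N)N` — compound 2 gives 14 nM
compound 3 `Cc1cc(N2CCCC(O)C2)c(S(C)(=O)=O)cc1C(=O)N=C(N)N` — compound 3 gives 30 nM

Compound 3 stands highest of the three numbers: a 2.1-fold higher number from compound 2 to compound 3 (0.33 log units; beyond the scatter) and a 5.3-fold higher number from compound 1 to compound 3 (0.72 log units; beyond the scatter). Compound 4 `Cc1cn(-c2cc(C)c(C(=O)N=C(N)N)cc2S(C)(=O)=O)cn1` differs from compound 3 on the same aromatic carbon: 4-methyl-1H-imidazol-1-yl in place of 3-hydroxypiperidin-1-yl on an aromatic carbon. All three measured steps exchange the group on this carbon, each modest in size: a 2.5-fold higher number from compound 1 to compound 2 (0.39 log units; beyond the scatter), a 5.3-fold higher number from compound 1 to compound 3 (0.72 log units; beyond the scatter), a 2.1-fold higher number from compound 2 to compound 3 (0.33 log units; beyond the scatter). None of them tests a five-membered aromatic group there, so the direction is open; a step no larger than modest in this assay is expected, and a lower number is somewhat more likely because compound 3 already gives the highest number at 30 nM. Compound 4 is expected at 20 nM, with a range of 6 nM to 60 nM, the expected step being a 1.5-fold lower number from compound 3 to compound 4 (0.18 log units; within the scatter).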

Compound 4, half-maximal inhibitory concentration: 28 nM
Compound 4: middle estimate off by 1.4-fold (0.15 log units), on the low side; the measured number falls inside the stated range.
By their numbers in this assay, from the lowest: compound 1; then compounds 2, 4 and 3 (each within the scatter of the next, the first and the last beyond it).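

In this assay, swapping the non-aromatic six-membered ring for a five-membered aromatic ring on this carbon, which also removes the hydrogen-bond donor, leaves the reading within the scatter (a 1.1-fold lower number from compound 3 to compound 4 (0.03 log units; within the scatter)). The 4-methyl-1H-imidazol-1-yl group also stays within the scatter of (2-chlorophenyl)sulfanyl (a 2.0-fold higher number from compound 2 to compound 4 (0.30 log units; within the scatter)), while propyl stays apart from it (a 4.9-fold higher number from compound 1 to compound 4 (0.69 log units; beyond the scatter)). No measurement at hand accounts for these steps.

Open, on these data alone, is whether a butyl chain or a dimethylamino group here would match propyl. Also open, as far as these compounds go, is whether unsubstituted imidazol-1-yl would read like its 4-methyl analogue.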